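This account rests on a few compounds, and the source may have more. Where it says the series, first, only, none or still open, it means among the compounds named here.

Series of sulfonamides on one shared core. Within the data shown here, compound 1 `Cc1ccccc1S(=O)(=O)NC(C1=CC(=O)c2c(O)ccc(O)c2C1=O)C(C)C` is the only member with a number: in a functional assay on HL-60 cells (Homo sapiens) for cytotoxicity, read by MTT assay (on this read-out higher numbers stand for weaker inhibition and lower numbers for stronger inhibition), compound 1 gives 190 nM. Compound 2 `CC(C)C(NS(=O)(=O)c1ccc(F)cc1)C1=CC(=O)c2c(O)ccc(O)c2C1=O` carries no result in this assay: for compound 2 the entry reads "not determined" (no result reported). Compound 3 `CC(C)C(NS(=O)(=O)c1ccc(Cl)cc1)C1=CC(=O)c2c(O)ccc(O)c2C1=O` also carries no result in this assay: for compound 3 the entry reads "not determined" (no result reported), so compound 3 stands nowhere on the numbers shown, and nothing ties it to compound 1 beyond the shared core. Compound 4 `CCOC(=O)c1ccc(S(=O)(=O)NC(C2=CC(=O)c3c(O)ccc(O)c3C2=O)C(C)C)cc1` is not yet measured. Compound 4 differs from compound 3 as follows: ethoxycarbonyl in place of chloro on an aromatic carbon. Among the measured compounds shown here, no measured step covers this change, so the size of step to expect in this assay is open; with compound 1 as the only anchor, no shift beyond the scatter is assumed in either direction. Compound 4 is expected to give about 250 nM in this assay, within 60 nM to 1000 nM.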

Compound 4, half-maximal inhibitory concentration: 150 nM
Estimate against measurement, compound 4: 1.7-fold (0.22 log units) above, within the range that was stated.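

In this assay, 4-(ethoxycarbonyl)phenyl in place of 2-methylphenyl on the sulfonyl sulfur gives a 1.3-fold lower number from compound 1 to compound 4 (0.10 log units; within the scatter), so the read-out does not separate these two groups, although they differ in both substituent and place on the phenyl group. The change from chloro to ethoxycarbonyl cannot be read, and neither can any other step to compound 2 or compound 3, as neither has a number. Nothing measured here offers an explanation for this result. Still open, from the compounds shown here alone, is how a carboxylic acid or an amine in place of ethoxycarbonyl would read, and whether a longer chain on the ester would hold the number.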